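A few compounds are considered here, and "the series" means these few. Any claim that something is new, unique, unknown or untested is made for them only; others in the source may bear on it.

Measured so far in a functional assay on KB cells (Homo sapiens) for antiproliferative activity, read by sulforhodamine B assay, with a stated time of 72 h; on this read-out lower numbers stand for stronger inhibition and higher numbers for weaker inhibition:
- compound 1 `O=C(/C=C/c1csc2ccccc12)c1ccccc1O`: 6200 nM
- compound 2 `O=C(/C=C/c1csc2ccccc12)c1cc(Br)ccc1O`: 760 nM
- compound 3 `O=C(/C=C/c1csc2ccccc12)c1cc(Br)cc(Br)c1O`: 4800 nM

Compound 2 has the lowest number of the three, and both of the steps that connect it to the other compounds lie beyond the scatter. Next is compound 4 `CCOc1ccc(O)c(C(=O)/C=C/c2csc3ccccc23)c1`, which differs from compound 2 at a single place: ethoxy in place of bromo on an aromatic carbon. This is ethoxy in place of bromo on an aromatic carbon, para to a hydroxy group.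

For the measured compounds named here, no measured step covers this exchange, and the series has no ethoxy compound so far. Two modest steps bear on it. Bromo in place of hydrogen at this same place gave an 8.2-fold lower number from compound 1 to compound 2 (0.91 log units; beyond the scatter). A further bromo in place of hydrogen gave a 6.3-fold higher number from compound 2 to compound 3 (0.80 log units; beyond the scatter), so the series has already moved in both directions through single changes. Removing the bromo from compound 2 might give back part of the first step, though ethoxy is not hydrogen and a full return is not assumed. A modest step to a higher number in this assay is therefore expected, with low confidence. The expected step is a 2.6-fold higher number from compound 2 to compound 4 (0.42 log units; beyond the scatter). For compound 4 the estimated value is 2000 nM, with an expected range of 600 nM to 6500 nM.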

Compound 4, half-maximal inhibitory concentration: 5800 nM
Compound 4: middle estimate off by 2.9-fold (0.46 log units), on the low side, within the range that was stated.
By their numbers in this assay, from the lowest: compound 2; then compounds 3, 4 and 1 (each within the scatter of the next).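

In this assay the gain at this place, on an aromatic carbon para to a hydroxy group, does not carry over to every group: ethoxy in place of bromo gives a 7.6-fold higher number from compound 2 to compound 4 (0.88 log units; beyond the scatter) and so lies beyond the scatter, which ties the low number of compound 2 to bromo rather than to any group replacing hydrogen here. Ethoxy in place of hydrogen gives a 1.1-fold lower number from compound 1 to compound 4 (0.03 log units; within the scatter) and leaves compound 4 and compound 1 indistinguishable on this read-out, whereas bromo in place of hydrogen at the same place gave an 8.2-fold lower number from compound 1 to compound 2 (0.91 log units; beyond the scatter) as a step beyond the scatter. The position therefore responds to the identity of the group and not merely to its being occupied, but nothing at hand accounts for the difference between bromo and ethoxy.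

On these data alone, whether chloro or iodo at this place would stay close to compound 2, or whether methoxy would stay close to compound 4, remains open. Also open, as far as these compounds go, is how an amine or a carboxylic acid at this place would compare with bromo and ethoxy in this assay.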